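The source may hold more compounds than are shown below. What is called first, only, known or untested is meant among the compounds shown, and "the series" means these compounds.

Three compounds have been measured in an in vitro functional assay on HEK285-7 cells for antagonist activity at prostaglandin D2 receptor 2 (Homo sapiens), read by BRET and beta-arrestin recruitment; on this read-out higher numbers stand for larger maximal responses and lower numbers for smaller maximal responses:
compound 1 `Nc1nc(-c2ccc(Cl)cc2)c(CC(=O)O)s1` gives 50%;
compound 2 `COc1ccc(OC)c(-c2nc(C(c3ccccc3)c3ccccc3)sc2CC(=O)O)c1` gives 80%;
compound 3 `Nc1cc(-c2nc(C(c3ccc(F)cc3)c3ccc(F)cc3)sc2CC(=O)O)cc(F)n1` gives 30%.

Compound 3 stands lowest of the three numbers. Its nearest neighbour is compound 1, whose value is higher by a margin beyond the usual scatter, and compound 2 lies further above it, also beyond the scatter. Compound 4 `O=C(O)Cc1sc(C(c2ccc(F)cc2)c2ccc(F)cc2)nc1-c1ccnc(N2CCC2)c1` has not yet been measured. It differs from compound 3 in one place: 2-(azetidin-1-yl)pyridin-4-yl in place of 2-amino-6-fluoropyridin-4-yl on an aromatic carbon. Among the measured compounds shown here, no step between two measured compounds isolates a change of this kind, so its direction cannot be read from the data. The expectation is a modest upward step, a number 15 percentage points higher from compound 3 to compound 4 (beyond the scatter), in this assay. Compound 4 is accordingly estimated at 45%, with a likely range from 20% to 75%.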

Compound 4, largest response reached (reported as efficacy), in percent of the reference or control that the assay uses: 80%
Beside the measured number, compound 4's estimate is 35 percentage points below it; the measured number lies above the stated range.
By their numbers in this assay, from the lowest: compound 3; then compound 1; then compounds 2 and 4 (each within the scatter of the next).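

In this assay, the group on this aromatic carbon, next to the ring nitrogen, has a large influence on the maximal response: 2-(azetidin-1-yl)pyridin-4-yl in place of 2-amino-6-fluoropyridin-4-yl gives a number 50 percentage points higher from compound 3 to compound 4 (beyond the scatter). This one swap removes the amino group and the fluorine and adds a four-membered ring, so it does not show which of these parts carries the step. Nothing available here explains the step.

Going by these compounds, it remains open whether a dimethylamino group or a pyrrolidine ring in place of the azetidine ring would give a response closer to compound 4 or to compound 3.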